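The source may hold more compounds than are shown below. What is called first, only, known or untested is meant among the compounds shown, and "the series" means these compounds.

Measured compounds in this series:

Compound 1, `O=[N+]([O-])c1cn2c(n1)OC(CNc1ccc(OC(F)(F)F)cc1)CC2`, gives >= 40000 nM in an ADME assay on MRC5 cells (Homo sapiens) for cytotoxicity, read by resazurin assay, with a stated time of 72 h (a lower number here means a stronger inhibitor, a higher number a weaker inhibitor), which is a limit of the assay and not a number. Compound 2, `CC1(CNc2ccc(OC(F)(F)F)cc2)CCn2cc([N+](=O)[O-])nc2O1`, gives >= 40000 nM in this assay, again a limit. Compound 3, `CC1(CNc2ccc(F)cc2)CCn2cc([N+](=O)[O-])nc2O1`, gives >= 40000 nM in this assay, also a limit.

Compound 1 therefore stands only at a limit of this assay, with no number of its own. Compound 4, `CN(CC1CCn2cc([N+](=O)[O-])nc2O1)c1ccc(OC(F)(F)F)cc1`, differs from compound 1 by a single change: methyl in place of hydrogen on a nitrogen on an aromatic ring. Two measured steps in this assay neighbour this change, a step that the two limits leave unreadable from compound 1 to compound 2 and a step that the two limits leave unreadable from compound 2 to compound 3, and neither yields a readable size, since the limit of >= 40000 nM in this assay, at which 3 of the 3 values shown sit, describes where all three measured compounds sit. No direction and no size beyond the scatter can be read for the step from compound 1 to compound 4; the expected step is a number no higher from compound 1 to compound 4 (the limit leaves the size open). Within the data shown here, compound 4 is estimated at 40000 nM, within a range of 20000 nM to 80000 nM, and is expected to return a limit again because the limit of >= 40000 nM in this assay, at which 3 of the 3 values shown sit, holds for every measured compound so far.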

Compound 4, half-maximal inhibitory concentration: >= 40000 nM
Compound 4: a limit, no number; the forecaster's own chance of this, stated with the estimate: 85%; the middle value lies on the limit itself.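

Among these compounds, compound 4, like compound 1, returns a limit of this assay and not a number, so no step between compound 1 and compound 4 can be read. The compounds shown leave open whether any change among them shifts the read-out at all, with every value resting on one limit: the limit of >= 40000 nM in this assay, at which 4 of the 4 values shown sit.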